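A Methyl on the Piperidine Ring: Compound 4 Awaits Its Number

The compounds below may be only part of what the source reports. "The series", "measured", "known", "first", "only" and "open" are said of these compounds alone.

Compound 1 `COc1cc2c(Nc3nc4ccc(C(=O)Nc5c(C)cccc5C)cc4s3)ncnc2cc1OCCCN1CCCCC1` gives > 100000 nM.
Compound 2 `COc1cc2c(Nc3nc4ccc(C(=O)Nc5c(C)cccc5C)cc4s3)ncnc2cc1OCCCN1CCC(C)CC1` gives > 100000 nM.
Compound 3 `COc1cc2c(Nc3nc4ccc(C(=O)Nc5c(C)cccc5Cl)cc4s3)ncnc2cc1OCCCN1CCCCC1` gives 23400 nM.

In a functional assay on HCT-116 cells (Homo sapiens) for cytotoxicity, read by WST assay, with a stated time of 72 h (on this read-out lower numbers stand for stronger inhibition and higher numbers for weaker inhibition), compound 1 gives > 100000 nM, which is a limit of the assay, not a number. Compound 2 likewise gives > 100000 nM, also a limit. For the measured compounds named here, compound 3 gives 23400 nM, the only number among the three. Compound 2 differs from compound 1 by methyl in place of hydrogen on a saturated ring carbon, and the step that the two limits leave unreadable from compound 1 to compound 2. Compound 3 differs from compound 1 by chloro in place of methyl on an aromatic carbon, a step of an at least 4.2-fold lower number from compound 1 to compound 3 (0.63 log units; beyond the scatter). Compound 4 `COc1cc2c(Nc3nc4ccc(C(=O)Nc5c(C)cccc5Cl)cc4s3)ncnc2cc1OCCCN1CCC(C)CC1` carries the same change that separates compound 2 from compound 1, now on the core of compound 3: methyl in place of hydrogen on a saturated ring carbon. Resting on the unreadable earlier step that the two limits leave unreadable from compound 1 to compound 2 and on compound 3 at 23400 nM, the expected step is a 1.1-fold higher number from compound 3 to compound 4 (0.03 log units; within the scatter). Compound 4 is estimated at 25000 nM, between 8000 nM and 100000 nM.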

Compound 4, half-maximal inhibitory concentration: 9100 nM
Beside the measured number, compound 4's estimate is 2.7-fold (0.44 log units) above it, and the stated range covers the measured number.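

In this assay, methyl in place of hydrogen on the piperidine ring gives a 2.6-fold lower number from compound 3 to compound 4 (0.41 log units; beyond the scatter), whereas the same change on the core of compound 1 cannot be read, since both of its values are limits. Chloro in place of methyl on the aromatic carbon gives an at least 10-fold lower number from compound 2 to compound 4 (1.04 log units; beyond the scatter), so that swap lowers the number on both cores, but its size cannot be compared between them: the same change on two cores in this assay, an at least 4.2-fold lower number (0.63 log units; beyond the scatter) from compound 1 to compound 3 and an at least 10-fold lower number (1.04 log units; beyond the scatter) from compound 2 to compound 4; the limit leaves it open whether they differ. Some of the values shown are limits rather than numbers, so this rests on very few compounds: the limit of > 100000 nM in this assay, at which 2 of the 4 values shown sit.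

The compounds shown leave open whether ethyl or hydroxyl in place of the ring methyl would lower the number further. They also leave open how fluoro in place of chloro on the aromatic carbon would behave.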